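From Methylamino to Dimethylamino on a Carbonyl Carbon

This account rests on a few compounds, and the source may have more. Where it says the series, first, only, none or still open, it means among the compounds named here.

Of the compounds shown here, three with a shared core have been measured in a functional assay on the whole organism with Mus musculus as the target, in the maximal electroshock model; a lower number here means that less compound is needed, a higher number that more compound is needed for the effect. Compound 1 `Clc1ccccc1-c1ccc(N2CCC3(CC2)OCCO3)nn1` gives 57 mg/kg, compound 2 `CCCC(=O)OC1CCN(c2ccc(-c3ccccc3Cl)nn2)CC1` gives 28 mg/kg, and compound 3 `CNC(=O)OC1CCN(c2ccc(-c3ccccc3Cl)nn2)CC1` gives 10 mg/kg. Compound 3 thus holds the lowest number of the three, and its gaps to both others lie beyond the scatter.

Compound 4 `CN(C)C(=O)OC1CCN(c2ccc(-c3ccccc3Cl)nn2)CC1` has not yet been measured. It differs from compound 3 by methyl in place of hydrogen on an amide-type nitrogen, which is methyl in place of hydrogen on an amide-type nitrogen, turning methylamino into dimethylamino.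

Among the measured compounds shown here, only one measured step bears on this change: a 2.8-fold lower number from compound 2 to compound 3 (0.45 log units; beyond the scatter), with methylamino in place of propyl on a carbonyl carbon. For the measured compounds named here, that modest step altered the group on the same carbonyl carbon, but no measured pair shows what a methyl does on this nitrogen, so it serves only as a loose guide to size. A change larger than that modest step is therefore not expected. The expected change is a 1.4-fold higher number from compound 3 to compound 4 (0.15 log units; within the scatter), a small rise that is estimated to stay within the scatter. Compound 4 is estimated at 14 mg/kg, with an expected range from 6 mg/kg to 35 mg/kg.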

Compound 4, dose for half-maximal effect: 2 mg/kg
Beside the measured number, compound 4's estimate is 7.0-fold (0.85 log units) above it, and the stated range ends above it.
By their numbers in this assay, from the lowest: compound 4; then compound 3; then compound 2; then compound 1.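

In this assay, the amide-type nitrogen proves to be a place where a single methyl in place of hydrogen has a clear effect: the number falls by a 5.0-fold lower number from compound 3 to compound 4 (0.70 log units; beyond the scatter), beyond the usual scatter. Among the compounds shown here, the earlier compounds could not show this, since their one measured step, a 2.8-fold lower number from compound 2 to compound 3 (0.45 log units; beyond the scatter), replaced the whole group on the carbonyl carbon and left open what a further methyl on this nitrogen would do; the two changes now read together as a 14-fold lower number from compound 2 to compound 4 (1.15 log units; beyond the scatter), the only large step among the steps between these compounds. Nothing available accounts for the size of the drop on going from methylamino to dimethylamino.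

The compounds shown leave open whether the trend continues or reverses with longer chains on this nitrogen, such as ethyl in diethylamino, and so whether methyl is a special case or the first point of a series. They also leave open whether the (dimethylcarbamoyl)oxy group would bring the same gain on a core carrying fluorine in place of chlorine.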